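The source may report more compounds than this note shows. Statements on the series, on what has been measured and on what is new or still open speak of the compounds shown alone.

Measured in a functional assay on MCF7 cells (Homo sapiens) for cytotoxicity, read by MTT assay, with a stated time of 48 h; on this read-out higher numbers stand for weaker inhibition and lower numbers for stronger inhibition:
compound 1 `Fc1ccc(-c2nc(-c3c[nH]c4ccccc34)co2)cc1`, 28000 nM
compound 2 `Clc1ccc(-c2nc(-c3c[nH]c4ccccc34)co2)cc1`, 410000 nM
compound 3 `C=Cc1nc(-c2c[nH]c3ccccc23)co1`, 103000 nM

Compound 3 stands second highest of these three numbers in this assay, with compound 1 nearest to it and compound 2 furthest from it. Compound 4 `c1ccc2c(-c3coc(C4CCNCC4)n3)c[nH]c2c1` differs from compound 3 by piperidin-4-yl in place of vinyl on an aromatic carbon. The measured steps that bear on this position are a 3.7-fold higher number from compound 1 to compound 3 (0.57 log units; beyond the scatter) and a 4.0-fold lower number from compound 2 to compound 3 (0.60 log units; beyond the scatter); both are modest and they run in opposite directions, so changes at this carbon have so far moved the number only modestly either way. None of them puts a piperidin-4-yl there, so the direction of the new step is open. Compound 4 is therefore expected to move by a 1.0-fold lower number from compound 3 to compound 4 (0.01 log units; within the scatter) in this assay, a step not beyond the scatter. The estimate for compound 4 is 100000 nM, with a range from 30000 nM to 400000 nM.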

Compound 4, half-maximal inhibitory concentration: 295000 nM
Estimate against measurement, compound 4: 3.0-fold (0.47 log units) below; low and high end bracket the measured number.
By their numbers in this assay, from the lowest: compound 1; then compound 3; then compounds 4 and 2 (each within the scatter of the next).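

In this assay, piperidin-4-yl on this aromatic carbon gives a 2.9-fold higher number from compound 3 to compound 4 (0.46 log units; beyond the scatter), and the comparison with the aryl compounds gives an 11-fold higher number from compound 1 to compound 4 (1.02 log units; beyond the scatter) and a 1.4-fold lower number from compound 2 to compound 4 (0.14 log units; within the scatter), the latter within the scatter. A non-aromatic ring at this position therefore does not reach the level of the 4-fluorophenyl compound, and it cannot be told apart from the 4-chlorophenyl compound. No measurement shown here accounts for these differences. As far as these compounds go, it remains open whether the ring nitrogen or the ring itself sets this step, and how a cyclohexyl group or an open aminoethyl chain would compare.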